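The source may hold more compounds than are shown below. What is called first, only, known or untested is meant among the compounds shown, and "the series" means these compounds.

Measured so far: compound 1 `CC1(C)CC(C)(C)c2cc(NC(=O)Nc3ccc(C(F)(F)F)cc3)ccc2O1` gives 88.4% in a functional assay on A2780 cells (Homo sapiens) for inhibition, with a stated time of 72 h, tested at 10 uM; a lower number here means less inhibition of growth, a higher number more inhibition of growth at the concentration tested; compound 3 `CC1(C)CC(C)(C)c2cc(NC(=O)Nc3ccc(OC(F)(F)F)cc3)ccc2O1` gives 91.5%; compound 2 `CC1(C)CCOc2ccc(NC(=O)Nc3ccc(OC(F)(F)F)cc3)cc21` gives 36%.

Compound 3 and compound 1 share one core and differ by trifluoromethyl in place of trifluoromethoxy on an aromatic carbon, a change that made a step of a number 3.1 percentage points lower from compound 3 to compound 1 (within the scatter). Compound 2 has a different core; how the two cores differ is not broken down here, but compound 2 sits far lower than compound 1 and compound 3. Compound 4 `CC1(C)CCOc2ccc(NC(=O)Nc3ccc(C(F)(F)F)cc3)cc21`, not yet measured, is compound 2 with the same change, (trifluoromethyl in place of trifluoromethoxy on an aromatic carbon). Because the earlier step of a number 3.1 percentage points lower from compound 3 to compound 1 (within the scatter) stayed within the scatter, the step from compound 2 to compound 4 is expected to be about as small, a number 2 percentage points lower from compound 2 to compound 4 (within the scatter). For compound 4 in this assay the estimate is 34%, between 18% and 50%.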

Compound 4, percent growth inhibition at one concentration: 47%
Compound 4: middle estimate off by 13 percentage points, on the low side, and the stated range covers the measured number.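

In this assay putting trifluoromethyl in place of trifluoromethoxy gave a number 11 percentage points higher from compound 2 to compound 4 (beyond the scatter) on the core of compound 2. The same change therefore did not carry over with the same result from one core to the other: the same change on two cores in this assay, a number 3.1 percentage points lower (within the scatter) from compound 3 to compound 1 and a number 11 percentage points higher (beyond the scatter) from compound 2 to compound 4, 14.1 percentage points apart, beyond the scatter of two such steps
This shows that, for these two pairs, the size of the step depends on the core it is made on, but two pairs cannot explain why or predict the step on a third core.

The compounds shown leave open what other groups would do at this place, para to a large group, such as a nitrile, an amine or a carboxylic acid. They also leave open whether a longer chain would give different steps on the two cores.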